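Swapping Trifluoromethyl for Chloro on Compound 1

This account rests on a few compounds, and the source may have more. Where it says the series, first, only, none or still open, it means among the compounds named here.

Of the compounds shown here, three have been tested in an assay on isolated protein for inhibition of malate dehydrogenase, mitochondrial (Sus scrofa), with stated times of 45 min and 30 min; on this read-out higher numbers stand for weaker inhibition and lower numbers for stronger inhibition. Compound 1 `O=S(=O)(Nc1ccc2oc(-c3ccccc3)nc2c1)c1cccc(C(F)(F)F)c1` gives > 63000 nM, which is a limit of the assay rather than a number. Compound 2 `O=S(=O)(Nc1ccc(-c2nc3ccccc3o2)cc1)c1cccc(O)c1` gives > 63000 nM, also a limit. Compound 3 `O=S(=O)(Nc1ccc(-c2nc3ccccc3o2)cc1)c1ccc(F)c(C(F)(F)F)c1` gives > 63000 nM, again a limit. Compound 1 therefore stands no differently from the other two because of the limit of > 63000 nM in this assay, at which 3 of the 3 values shown sit. Compound 4 `O=S(=O)(Nc1ccc2oc(-c3ccccc3)nc2c1)c1cccc(Cl)c1` has not been measured; it differs from compound 1 by chloro in place of trifluoromethyl on an aromatic carbon. Among the measured compounds shown here, no step between measured compounds exists, so the size of this change cannot be read from the data, and no shift beyond the scatter is expected in either direction. Compound 4 is expected to give 80000 nM in this assay, within 20000 nM to 300000 nM. For compound 4 the expected step is a step that the limit leaves unreadable from compound 1 to compound 4.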

Compound 4, half-maximal inhibitory concentration: > 63000 nM
Compound 4 ended at the assay's limit (the forecaster's own chance of this, stated with the estimate: 85%); the middle value lies beyond the limit too.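

No step from compound 1 to compound 4 can be read, because each compound gives a limit rather than a number: the limit of > 63000 nM in this assay, at which 4 of the 4 values shown sit.

The compounds shown leave open whether chloro and trifluoromethyl differ at all, and which structure would give a measurable value.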